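Terminal aryl swaps on the shared core

The source may report more compounds than this note shows. Statements on the series, on what has been measured and on what is new or still open speak of the compounds shown alone.

Measured so far:
compound 1 `Cc1oc(C(=O)O)cc1COc1ccc(-c2ccncc2)cc1` gives > 10000 nM
compound 2 `CNC(=O)c1ccc(-c2ccc(OCc3cc(C(=O)O)oc3C)cc2)cc1` gives > 10000 nM
compound 3 `COc1ccc(-c2ccc(OCc3cc(C(=O)O)oc3C)cc2)nc1` gives 1300 nM

Among the measured compounds shown here, in an assay on cells for displacement of a labelled ligand from prostaglandin E2 receptor EP4 subtype (Homo sapiens), read by scintillation counting (on this read-out higher numbers stand for weaker inhibition and lower numbers for stronger inhibition), compound 3 is the only member with an actual number, 1300 nM. For compound 1 the reported > 10000 nM is a limit of the assay, not a number. Compound 2 likewise reaches only a limit, > 10000 nM. For the measured compounds named here, the single measured step, an at least 7.6-fold lower number from compound 1 to compound 3 (0.88 log units; beyond the scatter), shows that exchanging the terminal aromatic ring shifts the read-out beyond the scatter, though its size is bounded only because of the limit of > 10000 nM in this assay, at which 2 of the 3 values shown sit.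

Compound 4 `Cc1oc(C(=O)O)cc1COc1ccc(-c2ccccc2)cc1` differs from compound 3 by phenyl in place of 5-methoxypyridin-2-yl on an aromatic carbon. Going by the values given here, no measured step introduces a phenyl, so the step from compound 1 to compound 3 bears on it only as a second swap of the same terminal ring, one that moved the number modestly. Two of the three terminal rings tried so far leave the compound at the limit, and compound 3 alone gives a number. The expectation for compound 4 is therefore a weaker result, quite possibly again only a limit. Compound 4 is estimated at 8000 nM, within 2000 nM to 30000 nM. That estimate means an expected step of a 6.2-fold higher number from compound 3 to compound 4 (0.79 log units; beyond the scatter), upward and beyond the scatter.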

Compound 4, inhibition constant: 420 nM
The estimate for compound 4 lay 19-fold (1.28 log units) above the measured number; the measured number lies below the stated range.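

In this assay compound 4, with the plain phenyl, is the strongest of the four shown, with a 3.1-fold lower number from compound 3 to compound 4 (0.49 log units; beyond the scatter), so the 5-methoxypyridin-2-yl is not needed for a measurable number on the shared core. Against the pyridin-4-yl the phenyl gives an at least 23-fold lower number from compound 1 to compound 4 (1.37 log units; beyond the scatter), and losing the methylcarbamoyl from that terminal ring gives an at least 23-fold lower number from compound 2 to compound 4 (1.37 log units; beyond the scatter), so an unsubstituted carbon ring serves better here than either of those terminal groups. Both of these larger steps are bounded on one side only: the limit of > 10000 nM in this assay, at which 2 of the 4 values shown sit.

Still open is whether a chlorine or a methoxy on the phenyl itself would keep or improve the number, with methylcarbamoyl the only substituent shown on that ring. Also open, as far as these compounds go, is whether a tetrazole could stand in for the carboxylic acid of the shared core.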